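Adding a Third Methyl Group: Compound 4 Estimated

This account rests on a few compounds, and the source may have more. Where it says the series, first, only, none or still open, it means among the compounds named here.

Measured compounds:
compound 1, `Cc1ccc(-n2cc(COc3ccc4c(c3)CCC4)nn2)c(C)c1`, 19.9%
compound 2, `c1ccc(-n2cc(COc3ccc4c(c3)CCC4)nn2)cc1`, 23.4%
compound 3, `Cc1cccc(-n2cc(COc3ccc4c(c3)CCC4)nn2)c1`, 23.4%

Of the compounds shown here, three have been tested in an ADME assay on HEK293 cells (Homo sapiens) for inhibition, read by MTT assay, with a stated time of 48 h, tested at 25 uM (on this read-out higher numbers stand for more inhibition at the one concentration tested (going by the name of the read-out) and lower numbers for less inhibition), and all three sit close together. Compound 1 stands lowest of the three, but only by steps that mean little: a number 3.5 percentage points higher from compound 1 to compound 2 (within the scatter), and a number 3.5 percentage points higher from compound 1 to compound 3 (within the scatter). Compound 1 and compound 2 differ in their cores as follows: 2,4-dimethylphenyl in place of phenyl on an aromatic nitrogen. Compound 3 differs from compound 2 by a single change, (methyl in place of hydrogen on an aromatic carbon), and that change produced no change at the digits printed from compound 2 to compound 3 (within the scatter).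

Compound 4, `Cc1cc(C)c(-n2cc(COc3ccc4c(c3)CCC4)nn2)c(C)c1`, has not yet been measured. It differs from compound 1 by methyl in place of hydrogen on an aromatic carbon. For the measured compounds named here, this is the same kind of change as the one from compound 2 to compound 3, but not the same change: in compound 4 the entering methyl sits ortho to a large group and meta to two methyl groups, whereas in compound 3 it sits meta to a large group.

For compound 4 in this assay an expected step of a number 1.1 percentage points higher from compound 1 to compound 4 (within the scatter) is set beside the earlier one, an expectation resting on compound 3 because no change at the digits printed from compound 2 to compound 3 (within the scatter). Compound 4 is therefore estimated at 21%, with a likely range from 10% to 34%.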

Compound 4, a percentage reported as inhibition, at one concentration (the size of the read-out at that concentration, not a potency): 16.6%
Estimate against measurement, compound 4: 4.4 percentage points above; the range from low to high includes it.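

In this assay, adding the methyl to the core of compound 1 gives a small step, a number 3.3 percentage points lower from compound 1 to compound 4 (within the scatter), and it can be set beside the earlier step for the same kind of change: the same change on two cores in this assay, no change at the digits printed (within the scatter) from compound 2 to compound 3 and a number 3.3 percentage points lower (within the scatter) from compound 1 to compound 4, 3.3 percentage points apart, within the scatter of two such steps. For these two pairs, then, the change carries from one core to the other without a difference that stands clear of the scatter, and neither step alone stands clear of it. For the compounds shown here, this does not show that the step would stay this small on other cores, nor that the two placements are interchangeable: only two pairs are at hand, the methyl enters at a different place in each, and in compound 4 it sits ortho to a large group, so a small real difference could remain hidden within the scatter.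

The compounds shown leave open how this read-out would respond if the methyl on the six-membered aromatic ring gave way to another group, such as a chlorine, a methoxy, an amine or a longer chain. They also leave open whether the same change would behave alike if the rest of the shared core were altered.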